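The compounds below may be only part of what the source reports. "The series", "measured", "known", "first", "only" and "open" are said of these compounds alone.

Measured in an ADME assay on MT4 cells (Homo sapiens) for cytotoxicity, read by MTT assay, with a stated time of 96 h; on this read-out higher numbers stand for lower toxicity in this test and lower numbers for higher toxicity in this test:
compound 1 `COc1ccc(-c2nc3cc(C(C)=O)ccc3[nH]2)c(OC)c1`: 50000 nM
compound 2 `COc1ccc(-c2nc3cc(/C(C)=N/NC(N)=O)ccc3[nH]2)c(OC)c1`: 21000 nM

Of these two numbers, the lower belongs to compound 2, at 21000 nM. The next compound, compound 3 `COc1ccc(-c2nc3cc(/C(C)=N/NC(N)=S)ccc3[nH]2)c(OC)c1`, differs from it in one place: a group of 3 heavy atoms (1 carbon, 1 nitrogen, 1 sulfur; no ring) in place of a group of 3 heavy atoms (1 carbon, 1 nitrogen, 1 oxygen; no ring), on an amine nitrogen. The carbamoyl group leaves, and a group with sulfur where the oxygen stood enters, on an amine nitrogen. Within the data shown here, no measured pair shows this swap. Among the measured compounds shown here, the one measured step, a 2.4-fold lower number from compound 1 to compound 2 (0.38 log units; beyond the scatter), changed a different group on an aromatic carbon, so it is only a loose guide. A modest move towards a lower number in this assay is expected, of similar size to that step, though a result within the scatter would be no surprise. The step this implies is estimated as a 2.1-fold lower number from compound 2 to compound 3 (0.32 log units; beyond the scatter). For compound 3 the estimate is 10000 nM, with an expected range from 3000 nM to 25000 nM.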

Compound 3, half-maximal cytotoxic concentration: 72000 nM
Compound 3: middle estimate off by 7.2-fold (0.86 log units), on the low side; measured number above the stated range.
By their numbers in this assay, from the lowest: compound 2; then compounds 1 and 3 (each within the scatter of the next).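

In this assay the swap of oxygen for sulfur on this amine nitrogen gives a 3.4-fold higher number from compound 2 to compound 3 (0.54 log units; beyond the scatter), so a single atom in this group is enough to shift the number, here towards lower toxicity in this test. Adding the side chain to the core does not by itself bring a lower number: the sulfur version gives a 1.4-fold higher number from compound 1 to compound 3 (0.16 log units; within the scatter), which puts compound 3 within the scatter of the simple carbonyl compound, while the oxygen version gave a 2.4-fold lower number from compound 1 to compound 2 (0.38 log units; beyond the scatter). Nothing measured here explains why the two atoms behave differently.

From the compounds shown here alone, it remains open how a methyl group, an acetyl group or a longer chain would behave in place of the carbamoyl group on this amine nitrogen. Whether the same swap gives a step of this kind on a different core also stays unanswered.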